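Swapping phenyl for bromo: compound 3 to compound 4

This account rests on a few compounds, and the source may have more. Where it says the series, first, only, none or still open, it means among the compounds named here.

Values in an ADME assay on Vero cells (Chlorocebus sabaeus) for cytotoxicity, read by resazurin assay, with a stated time of 72 h (a lower number here means that less compound is tolerated, a higher number that more compound is tolerated), stand as follows:

- compound 1 `CC(C)(C)c1ccc(C(=O)/C=C/c2ccco2)cc1` gives "not determined" (no result reported)
- compound 2 `O=C(/C=C/c1ccc([N+](=O)[O-])s1)c1ccc(-n2ccnc2)cc1` gives 42700 nM
- compound 3 `O=C(/C=C/c1ccc([N+](=O)[O-])o1)c1ccc(-c2ccccc2)cc1` gives > 100000 nM (a limit)

Compound 3 has > 100000 nM as its only entry, and that entry is a limit of the assay and not a number. Compound 4 `O=C(/C=C/c1ccc([N+](=O)[O-])o1)c1ccc(Br)cc1` carries bromo in place of the phenyl of compound 3, on an aromatic carbon of a six-membered aromatic ring of carbon only, para to a large group (bromo in place of phenyl on an aromatic carbon). Within the data shown here, no two measured compounds differ in one place, so this assay offers no measured step by which to scale this change. Among the measured compounds shown here, with compound 2 at 42700 nM as the only number in hand, a moderate move toward less compound tolerated is expected. The estimated change is an at least 2.2-fold lower number from compound 3 to compound 4 (0.34 log units; beyond the scatter) (expected, not measured). For compound 4 the estimated half-maximal cytotoxic concentration is 45000 nM (expected range 12000 nM to 100000 nM).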

Compound 4, half-maximal cytotoxic concentration: > 100000 nM
Compound 4 gave a limit, no number (the forecaster's own chance of this, stated with the estimate: 30%); middle value at least 2.2-fold (0.34 log units) from the limit.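

Compound 3 and compound 4 both rest on a limit rather than a number, so the swap of phenyl for bromo yields no readable step in this assay: the limit of > 100000 nM in this assay, at which 2 of the 4 values shown sit. The compounds shown leave open whether phenyl and bromo differ at all in this assay, and by how much.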